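Swapping 4-pentylphenyl for phenethyl on a triple bond

The source may hold more compounds than are shown below. What is called first, only, known or untested is meant among the compounds shown, and "the series" means these compounds.

Measured so far in a functional assay on SW-620 cells (Homo sapiens) for antiproliferative activity, read by MTT assay, with a stated time of 3 days; on this read-out lower numbers stand for stronger inhibition and higher numbers for weaker inhibition:
Compound 1 `Cc1ccc(C#Cc2cn(C/C=C\CN3C(=O)c4ccccc4C3=O)c(=O)[nH]c2=O)cc1`: > 100000 nM, a limit
Compound 2 `O=C1c2ccccc2C(=O)N1C/C=C\Cn1cc(C#Cc2ccc(Br)cc2)c(=O)[nH]c1=O`: > 100000 nM, a limit
Compound 3 `CCCCCc1ccc(C#Cc2cn(C/C=C\CN3C(=O)c4ccccc4C3=O)c(=O)[nH]c2=O)cc1`: > 100000 nM, a limit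

Compound 3 gives > 100000 nM in this assay, which is a limit and not a number. Compound 1 and compound 2 also report only a limit, so none of the three has a readable potency. Compound 4 `O=C1c2ccccc2C(=O)N1C/C=C\Cn1cc(C#CCCc2ccccc2)c(=O)[nH]c1=O` keeps the shared core, with phenethyl in place of 4-pentylphenyl on a triple-bonded carbon.

Within the data shown here, three measured steps bear on this change, and none has a readable size: a step that the two limits leave unreadable from compound 1 to compound 2, a step that the two limits leave unreadable from compound 1 to compound 3 and a step that the two limits leave unreadable from compound 2 to compound 3. All three compounds share one ceiling, (the limit of > 100000 nM in this assay, at which 3 of the 3 values shown sit). None of them carries phenethyl, so the evidence is indirect, but it gives no reason to expect a change in either direction beyond the scatter. The estimated step is a number no higher from compound 3 to compound 4 (the limit leaves the size open). Compound 4 is expected near 100000 nM, with an estimated range of 40000 nM to 150000 nM, and will most likely be reported only as a limit.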

Compound 4, half-maximal inhibitory concentration: > 100000 nM
Compound 4 ended at the assay's limit; the forecaster's own chance of this, stated with the estimate: 85%; the middle value sits exactly at the limit.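

No step from compound 1, compound 2 or compound 3 to compound 4 can be read, since each compound reports only a limit: the limit of > 100000 nM in this assay, at which 4 of the 4 values shown sit.

The compounds shown leave open how potent any of them is in this assay, and whether swapping these groups changes that potency at all.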